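Amide for amine on the pyrrolidine of a quinolone carboxylic acid

A few compounds are considered here, and "the series" means these few. Any claim that something is new, unique, unknown or untested is made for them only; others in the source may bear on it.

The measured compounds:
Compound 1, `N[C@@H]1CCN(c2cc3c(cc2F)c(=O)c(C(=O)O)cn3Cc2ccc(-c3ccccc3)cc2)C1`, 63600 nM
Compound 2, `COc1c(N2CC[C@@H](N)C2)c(F)cc2c(=O)c(C(=O)O)cn(Cc3ccc(-c4ccccc4)cc3)c12`, 92200 nM
Compound 3, `COc1c(N2CC[C@@H](N)C2)c(F)cc2c(=O)c(C(=O)O)cn(Cc3ccc(-c4ccc(F)cc4)cc3)c12`, 58600 nM

All three were tested in an assay on isolated protein for inhibition of DNA topoisomerase 1 (Homo sapiens), with a stated time of 15 min; on this read-out higher numbers stand for weaker inhibition and lower numbers for stronger inhibition. Compound 2 gives the highest number of the three, but the step that reaches it is only a 1.4-fold higher number from compound 1 to compound 2 (0.16 log units; within the scatter) and the step that leaves it only a 1.6-fold lower number from compound 2 to compound 3 (0.20 log units; within the scatter), so the three compounds are indistinguishable within the scatter of this assay.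

Compound 4, `COc1c(N2CC[C@@H](C(N)=O)C2)c(F)cc2c(=O)c(C(=O)O)cn(Cc3ccc(-c4ccccc4)cc3)c12`, has not yet been measured. It differs from compound 2 by carbamoyl in place of amino on a saturated ring carbon. Neither measured step bears on this change: the step from compound 1 to compound 2 is a methoxy in place of hydrogen on an aromatic carbon, and the step from compound 2 to compound 3 is a fluoro in place of hydrogen on an aromatic carbon, and both lie within the scatter. Within the data shown here, there is no measured step at the saturated ring carbon of the five-membered ring, so no direction can be drawn from the data. Compound 4 is therefore expected to give about 100000 nM in this assay, in the range 40000 nM to 300000 nM, which would mean a step of a 1.1-fold higher number from compound 2 to compound 4 (0.04 log units; within the scatter), a step not expected to exceed the scatter.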

Compound 4, half-maximal inhibitory concentration: > 200000 nM
Compound 4 gave a limit, no number; the forecaster's own chance of this, stated with the estimate: 25%; at least 2.0-fold (0.30 log units) between middle value and limit.
By their numbers in this assay, from the lowest: compounds 3, 1 and 2 (each within the scatter of the next). At a limit, above all of these: compound 4.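

Compound 4 gives > 200000 nM in this assay, and this value is a limit of the assay, not a number. Carbamoyl in place of amino on the saturated ring carbon of the five-membered ring gives an at least 2.1-fold higher number from compound 2 to compound 4 (0.33 log units; beyond the scatter), so this position, unlike the two aromatic carbons changed in the earlier steps, has produced a change beyond the scatter, in the direction of weaker inhibition. The step gives only the least size of the change, and how far compound 4 lies past it remains unknown: the limit of > 200000 nM in this assay, at which 1 of the 4 values shown sits.

The compounds shown leave open which feature of the change from 3-aminopyrrolidin-1-yl to 3-carbamoylpyrrolidin-1-yl matters, since a hydroxyl, a methylamino group, an aminomethyl group or a carboxylic acid on the same ring carbon would each separate the loss of the amino group from the arrival of the carbamoyl group. They also leave open whether the same change would carry over to the core of compound 1, which lacks the methoxy group, or to compound 3, which carries the extra fluoro group.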